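From Compound 3 to Compound 4: Adding a Butyl Group

This account rests on a few compounds, and the source may have more. Where it says the series, first, only, none or still open, it means among the compounds named here.

Measured compounds:
compound 1, `N#C[Se]c1ccc(NC(=O)OCc2ccccc2)cc1`, 27600 nM
compound 2, `CCCCOC(=O)Nc1ccc([Se][Se]c2ccc(NC(=O)OCCCC)cc2)cc1`, 35200 nM
compound 3, `CCOC(=O)Nc1ccc([Se]C#N)cc1`, 24900 nM

In a functional assay on HTB-54 cells (Homo sapiens) for cytotoxicity, read by MTT assay, with a stated time of 72 h (on this read-out higher numbers stand for weaker inhibition of growth and lower numbers for stronger inhibition of growth), compound 3 gives the lowest of the three numbers, yet its gaps to compound 1 and compound 2 both lie within the scatter, so no order among them can be claimed. Compound 4 `CCCCCCOC(=O)Nc1ccc([Se]C#N)cc1` differs from compound 3 by butyl in place of hydrogen on a saturated chain carbon, two bonds along the chain from an oxygen next to a carbonyl group. Within the data shown here, the only measured step at this part of the molecule is a 1.1-fold lower number from compound 1 to compound 3 (0.04 log units; within the scatter), which changed nothing beyond the scatter. Among the measured compounds shown here, compound 2 carries a butyl chain on the same side but differs elsewhere too, so it gives no clean step. The expectation is therefore a step of a 1.1-fold lower number from compound 3 to compound 4 (0.05 log units; within the scatter), within the scatter. Compound 4 is estimated at 22000 nM, between 9000 nM and 55000 nM.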

Compound 4, concentration for 50% growth inhibition: 23600 nM
Compound 4: the middle estimate sits 1.1-fold (0.03 log units) below what was measured; low and high end bracket the measured number.
By their numbers in this assay, from the lowest: compounds 4, 3, 1 and 2 (each within the scatter of the next).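

In this assay, butyl in place of hydrogen at this position gives a 1.1-fold lower number from compound 3 to compound 4 (0.02 log units; within the scatter), and pentyl in place of phenyl gives a 1.2-fold lower number from compound 1 to compound 4 (0.07 log units; within the scatter). Both steps lie within the scatter, so a much longer chain, hexyl, now joins ethyl and the phenyl-bearing group of compound 1 with no readable difference among these three compounds. No supporting measurement bears on this result. From the compounds shown here alone, whether an amine or a carboxylic acid on this chain, or a chain longer than hexyl, would move the number remains open.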